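Fluoro to methyl from compound 2

The compounds below may be only part of what the source reports. "The series", "measured", "known", "first", "only" and "open" are said of these compounds alone.

Measured so far in a physicochemical assay for solubility, read by nephelometry, in phosphate buffer, measured as kinetic solubility, at pH 2; on this read-out lower numbers stand for lower solubility and higher numbers for higher solubility:
- compound 1 `O=C(Nc1ccc(F)c(-c2nc3ncccc3o2)c1)c1cnco1` gives 6.3 ug/mL
- compound 2 `O=C(Nc1ccc(F)c(-c2nc3ncccc3o2)c1)c1ccoc1` gives 12.5 ug/mL
- compound 3 `Cc1ccoc1C(=O)Nc1ccc(F)c(-c2nc3ncccc3o2)c1` gives 1.6 ug/mL

Compound 2 belongs to the top of these numbers: its nearest gap lies within the scatter (a 2.0-fold higher number from compound 1 to compound 2 (0.30 log units; within the scatter)) and its furthest does not (a 7.8-fold lower number from compound 2 to compound 3 (0.89 log units; beyond the scatter)).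

Compound 4 `Cc1ccc(NC(=O)c2ccoc2)cc1-c1nc2ncccc2o1` differs from compound 2 as follows: methyl in place of fluoro on an aromatic carbon.

Going by the values given here, no measured step touches that place. Among the compounds with values here, all three changed the group on the carbonyl carbon, so they gauge size only, and the data hold no direct precedent. A small expected shift to a lower number, within the scatter, is written as a 1.8-fold lower number from compound 2 to compound 4 (0.25 log units; within the scatter) in this assay for now. Compound 4 is estimated at 7 ug/mL with an expected range from 2.5 ug/mL to 18 ug/mL for this read-out.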

Compound 4, solubility: 12.5 ug/mL
Estimate against measurement, compound 4: 1.8-fold (0.25 log units) below; the range from low to high includes it.
By their numbers in this assay, from the lowest: compound 3; then compounds 1, 2 and 4 (each within the scatter of the next).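

Going by these compounds alone, on this aromatic carbon, para to the ((furan-3-yl)carbonyl)amino group, methyl in place of fluoro gives no change at the digits printed from compound 2 to compound 4 (within the scatter) in this assay and is the first step read at this position, as the earlier steps all changed the group on the carbonyl carbon. With the furan-3-yl group held fixed, fluoro and methyl here therefore read alike. Nothing on hand explains this result.

From the compounds shown here alone, whether the same swap reads alike with 1,3-oxazol-5-yl or 3-methylfuran-2-yl on the carbonyl carbon remains open. So does how an amine or a carboxylic acid on this aromatic carbon would read.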